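Replacing tert-butyl with phenyl on a sigma receptor ligand

The compounds below may be only part of what the source reports. "The series", "measured", "known", "first", "only" and "open" are said of these compounds alone.

Compound 1 `CC(C)c1ccc(-c2nc(CN3CCCC3)nn2C)cc1` in an assay on membranes from Jurkat cells for displacement of a labelled ligand from Sigma non-opioid intracellular receptor 1 (Homo sapiens), read by scintillation counting, with a stated time of 2 h; on this read-out lower numbers stand for stronger inhibition and higher numbers for weaker inhibition: 96 nM
Compound 2 `Cn1nc(CN2CCCC2)nc1-c1ccc(C(C)(C)C)cc1` in this assay : 7.5 nM

Of the two measured compounds, compound 2 stands at the lower number; the step of a 13-fold lower number from compound 1 to compound 2 (1.11 log units; beyond the scatter) lies beyond the scatter, so compound 2 is the stronger binder of the two. Compound 3 `Cn1nc(CN2CCCC2)nc1-c1ccc(-c2ccccc2)cc1` has not been measured yet. It differs from compound 2 in one place: phenyl in place of tert-butyl on an aromatic carbon. Going by the values given here, only one measured step exists, the one from compound 1 to compound 2, and it concerns a different change at the same end of the shared core, a methyl put in place of a hydrogen on a saturated chain carbon. It shows that altering that end of the molecule can move the number well beyond the scatter, but it does not show in which direction a phenyl in place of tert-butyl will move it. Among the compounds with values here, with no measured step on the same change, the expectation stays close to compound 2 with a wide range on both sides. For compound 3 the estimated value is 20 nM, between 3 nM and 120 nM, which means an expected step of a 2.7-fold higher number from compound 2 to compound 3 (0.43 log units; beyond the scatter).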

Compound 3, inhibition constant: 90 nM
Compound 3: middle estimate off by 4.5-fold (0.65 log units), on the low side; the measured number falls inside the stated range.
By their numbers in this assay, from the lowest: compound 2; then compounds 3 and 1 (each within the scatter of the next).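

In this assay, phenyl in place of tert-butyl on the aromatic carbon gives a 12-fold higher number from compound 2 to compound 3 (1.08 log units; beyond the scatter) and so weakens binding, which settles a direction the earlier pair could not show for this change. Phenyl in place of isopropyl gives a 1.1-fold lower number from compound 1 to compound 3 (0.03 log units; within the scatter) and leaves those two compounds indistinguishable, even though the phenyl group brings a six-membered aromatic ring. Compound 2 is therefore the strongest binder of the three, and a simple rule that more heavy atoms at this place give tighter binding fails, since compound 3 goes against it: phenyl has 6 heavy atoms and tert-butyl 4, yet tert-butyl gives the stronger binder.

Still open, from the compounds shown here alone, is whether the advantage belongs to tert-butyl alone or would also appear with another group at this place, such as cyclohexyl, trifluoromethyl or a primary amine. Nothing available here explains why these groups differ.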